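From Hydroxymethyl to 4-Fluorophenyl: What Compound 4 Might Show

This account rests on a few compounds, and the source may have more. Where it says the series, first, only, none or still open, it means among the compounds named here.

Compound 1, `CCOC(=O)c1cn(C(c2ccccc2)c2cc3cc(Br)ccc3nc2OC)nn1`: -3.67%
Compound 2, `COc1nc2ccc(Br)cc2cc1C(c1ccccc1)n1cc(CCCO)nn1`: 11.3%
Compound 3, `COc1nc2ccc(Br)cc2cc1C(c1ccccc1)n1cc(CO)nn1`: 0.25%

Three compounds sharing one core were measured in an ADME assay on HeLa cells (Homo sapiens) for cytotoxicity, read by sulforhodamine B assay, with a stated time of 48 h, tested at 10 uM; a higher number here means more inhibition at the concentration tested (going by the name of the read-out), a lower number less inhibition. Compound 3 holds the second highest number of the three; its nearest neighbour is compound 1, with a number 3.9 percentage points higher from compound 1 to compound 3 (within the scatter), and its furthest is compound 2, with a number 11.1 percentage points lower from compound 2 to compound 3 (beyond the scatter).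

Compound 4, `COc1nc2ccc(Br)cc2cc1C(c1ccccc1)n1cc(-c2ccc(F)cc2)nn1`, is not yet measured. It differs from compound 3 at the aromatic carbon of the five-membered ring with three nitrogens: 4-fluorophenyl in place of hydroxymethyl on an aromatic carbon. Within the data shown here, no measured step exchanges a group for an aryl ring, but both steps into compound 3 changed this same position, one within the scatter and one modest. A small step in this assay is therefore expected, a number 7.8 percentage points higher from compound 3 to compound 4 (within the scatter), perhaps slightly upward. Compound 4 is estimated at 8%, between -10% and 26%.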

Compound 4, a percentage reported as inhibition, at one concentration (the size of the read-out at that concentration, not a potency): 4.27%
Estimate against measurement, compound 4: 3.7 percentage points above; measured number inside the range.
By their numbers in this assay, from the lowest: compounds 1, 3, 4 and 2 (each within the scatter of the next, the first and the last beyond it).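

Among these compounds, at this aromatic carbon, an aryl ring for the first time gives a number within the scatter of all three earlier groups in this assay: hydroxymethyl (a number 4 percentage points higher from compound 3 to compound 4 (within the scatter)), 3-hydroxypropyl (a number 7 percentage points lower from compound 2 to compound 4 (within the scatter)) and ethoxycarbonyl (a number 7.9 percentage points higher from compound 1 to compound 4 (within the scatter)). The larger 4-fluorophenyl, with its six-membered aromatic ring, thus brings no step beyond the scatter from any of them. Nothing available explains this result.

On these data alone, whether an amine or a carboxylic acid on this carbon would give a step beyond the scatter remains open. So does the effect of a chain longer than 3-hydroxypropyl.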